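This account rests on a few compounds, and the source may have more. Where it says the series, first, only, none or still open, it means among the compounds named here.

Measured compounds:
compound 1 `O=C(/C=C\Nc1ccc2cc[nH]c2c1)c1nc(-c2ccc(C(F)(F)F)cc2)n2ccccc12` — > 30000 nM
compound 2 `COc1ccc(N/C=C\C(=O)c2nc(-c3ccc(OC)cc3)n3ccccc23)cc1` — > 30000 nM

In a functional assay on MDA-MB-231 cells (Homo sapiens) for cytotoxicity, read by MTT assay, with a stated time of 48 h (on this read-out lower numbers stand for stronger inhibition and higher numbers for weaker inhibition), compound 1 gives > 30000 nM, which is a limit of the assay rather than a number. In this assay compound 2 likewise gives > 30000 nM, again a limit. Among the measured compounds shown here, compound 1 therefore cannot be placed in any order against compound 2: both sit at the limit of > 30000 nM in this assay, at which 2 of the 2 values shown sit, and no step between them can be counted.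

Compound 3 `O=C(/C=C\Nc1ccc(F)cc1)c1nc(-c2ccc(C(F)(F)F)cc2)n2ccccc12` is not yet measured. It differs from compound 1 in one place: 4-fluorophenyl in place of 1H-indol-6-yl on an amine nitrogen. For the measured compounds named here, no measured pair shows what this exchange does, so nothing supports a step of any size or direction beyond the scatter. Given that both measured compounds rest at a limit, the expected step of a number no higher from compound 1 to compound 3 (the limit leaves the size open) is none beyond the scatter, and compound 3 is estimated to give 30000 nM, in the range 10000 nM to 100000 nM.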

Compound 3, half-maximal inhibitory concentration: > 30000 nM
Compound 3: a limit, no number; the forecaster's own chance of this, stated with the estimate: 75%; the middle value sits exactly at the limit.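

In this assay compound 3 gives > 30000 nM, which is a limit. Compound 1 also rests at a limit, so no step between compound 1 and compound 3 can be read: the limit of > 30000 nM in this assay, at which 3 of the 3 values shown sit.

The compounds shown leave open what placing 4-fluorophenyl in place of 1H-indol-6-yl does to the read-out.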